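Amino for morpholin-4-yl on the carbonyl carbon

A few compounds are considered here, and "the series" means these few. Any claim that something is new, unique, unknown or untested is made for them only; others in the source may bear on it.

In a functional assay on MDA-MB-231 cells (Homo sapiens) for inhibition, read by sulforhodamine B assay, with a stated time of 72 h (on this read-out higher numbers stand for weaker inhibition of growth and lower numbers for stronger inhibition of growth), compound 1 `CN1CCN(C(=O)/C=C/c2ccncc2-c2ccc3ccccc3c2)CC1` gives > 10000 nM, which is a limit of the assay and not a number. Compound 2 `CNC(=O)CCc1ccncc1-c1ccc2ccccc2c1` gives 8980 nM. Compound 3 `O=C(/C=C/c1ccncc1-c1ccc2ccccc2c1)N1CCOCC1` gives 8980 nM, level with compound 2.

Compound 4 `NC(=O)/C=C/c1ccncc1-c1ccc2ccccc2c1` carries amino in place of morpholin-4-yl on a carbonyl carbon. Among the compounds with values here, the only measured step at this carbonyl is an at least 1.1-fold lower number from compound 1 to compound 3 (0.04 log units; that floor lies within the scatter). Its size is only a floor, as the limit of > 10000 nM in this assay, at which 1 of the 3 values shown sits, shows. Within the data shown here, no measured step introduces amino, so the basis is thin. In this assay, no step beyond the scatter is expected, and no direction is favoured. The expected change is a 1.3-fold lower number from compound 3 to compound 4 (0.11 log units; within the scatter). Compound 4 is estimated at 7000 nM, with an expected range of 2500 nM to 15000 nM.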

Compound 4, concentration for 50% growth inhibition: > 10000 nM
Compound 4 gave a limit, no number; the forecaster's own chance of this, stated with the estimate: 40%; middle value at least 1.4-fold (0.15 log units) from the limit.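

In this assay compound 4 gives > 10000 nM, a limit of the assay and not a number. Amino on the carbonyl carbon gives an at least 1.1-fold higher number from compound 3 to compound 4 (0.04 log units; that floor lies within the scatter), and the change of side chain gives an at least 1.1-fold higher number from compound 2 to compound 4 (0.04 log units; that floor lies within the scatter); neither shows stronger inhibition of growth, and the step from compound 1 to compound 4 cannot be read. Both readable sizes are only floors: the limit of > 10000 nM in this assay, at which 2 of the 4 values shown sit.

On these data alone, how far compound 4 truly lies from compound 3 stays open. Also open, as far as these compounds go, is whether a carboxylic acid or a longer amine chain on this carbonyl carbon would give a clearly stronger read-out.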